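The source may report more compounds than this note shows. Statements on the series, on what has been measured and on what is new or still open speak of the compounds shown alone.

Compound 3 `Cc1ccc(-n2c(=O)n(Cc3cc4cc(Cl)ccc4n3CCCC#N)c3cnccc32)cc1` sits in an ADME assay on HeLa cells (Homo sapiens) for cytotoxicity, read by ATP content, with a stated time of 3 days (a lower number here means that less compound is tolerated, a higher number that more compound is tolerated), at a limit of the assay, > 50000 nM. Compound 1 `N#CCCCn1c(Cn2c(=O)n(-c3ccc(C(=O)NC4CC4)cc3)c3ccncc32)cc2cc(Cl)ccc21` returns in this assay only a limit as well, > 50000 nM. Compound 2 `N#CCCCn1c(Cn2c(=O)n(-c3ccc(OC(F)(F)F)cc3)c3ccncc32)cc2cc(Cl)ccc21` likewise gives only a limit there, > 50000 nM. All three values rest at the limit of > 50000 nM in this assay, at which 3 of the 3 values shown sit, so the steps a step that the two limits leave unreadable from compound 1 to compound 3, a step that the two limits leave unreadable from compound 2 to compound 3 and a step that the two limits leave unreadable from compound 1 to compound 2 cannot be read; no change on the aromatic carbon moved any compound off the limit. Compound 4 `COc1ccc(-n2c(=O)n(Cc3cc4cc(Cl)ccc4n3CCCC#N)c3cnccc32)c(C)c1` carries the change (4-methoxy-2-methylphenyl in place of 4-methylphenyl on an aromatic nitrogen). Among the measured compounds shown here, the three unreadable steps are the only comparisons available and bear on this change only by showing no reading anywhere; the expected step that the limit leaves unreadable from compound 3 to compound 4 is therefore none beyond the scatter, with a limit again the most likely outcome. Compound 4 is estimated at 60000 nM, between 20000 nM and 150000 nM.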

Compound 4, half-maximal cytotoxic concentration: > 50000 nM
Compound 4 ended at the assay's limit; the forecaster's own chance of this, stated with the estimate: 85%; the middle value is on the limit's open side.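

The steps joining compound 4 to compound 1, compound 2 and compound 3 cannot be read, since all four compounds rest at one limit: the limit of > 50000 nM in this assay, at which 4 of the 4 values shown sit.

The compounds shown leave open at what concentration any of them would register as cytotoxic in this assay, and whether these aryl changes alter that.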